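The source may hold more compounds than are shown below. What is called first, only, known or untested is meant among the compounds shown, and "the series" means these compounds.

Two amides with the same core have been measured in a functional assay on B16-F10 cells (Mus musculus) for inhibition, read by MTT assay, with a stated time of 48 h; a higher number here means a weaker inhibitor, a lower number a stronger inhibitor. Compound 1 (`COc1ccc(/C=C/c2cc(OC)cc(OC)c2/C=C/C(=O)NC2CC2)cc1`) gives 10200 nM, and compound 2 (`COc1ccc(/C=C/c2cc(OC)cc(OC)c2/C=C/C(=O)N2CCC(c3ccccc3)CC2)cc1`) gives 9180 nM. These two numbers lie within the scatter of each other, so compound 2 stands level with compound 1. Compound 3 (`CCCCCCNC(=O)/C=C/c1c(/C=C/c2ccc(OC)cc2)cc(OC)cc1OC`) keeps the core and changes only the amide group: hexylamino in place of 4-phenylpiperidin-1-yl on a carbonyl carbon. For the measured compounds named here, the only measured step, a 1.1-fold lower number from compound 1 to compound 2 (0.05 log units; within the scatter), also exchanged the group on this carbonyl carbon, and it produced no change beyond the scatter. That is thin evidence, since it is a single step and no open-chain group such as hexylamino has yet been measured here. The expected step in this assay is a 1.0-fold lower number from compound 2 to compound 3 (0.01 log units; within the scatter), which would be none beyond the scatter. For compound 3 the estimated value is 9000 nM, with an expected range from 4000 nM to 20000 nM.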

Compound 3, half-maximal inhibitory concentration: 7180 nM
Beside the measured number, compound 3's estimate is 1.3-fold (0.10 log units) above it; the range from low to high includes it.
By their numbers in this assay, from the lowest: compounds 3, 2 and 1 (each within the scatter of the next).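

In this assay, for the compounds shown here, hexylamino is the first open-chain group at this carbonyl carbon, and it brings back the amide hydrogen that 4-phenylpiperidin-1-yl lacks, yet a 1.3-fold lower number from compound 2 to compound 3 (0.11 log units; within the scatter) is all that follows. Hexyl in place of cyclopropyl on the amide-type nitrogen brings a 1.4-fold lower number from compound 1 to compound 3 (0.15 log units; within the scatter) as well, so all three compounds stand level, whether the group holds a ring or an open chain and whether the amide hydrogen is present or absent. Nothing shown here accounts for this flat result.

Still open, on these data alone, is whether a chain carrying an amine or a carboxylic acid, or a much longer chain such as dodecyl, would move the number beyond the scatter. Also open, as far as these compounds go, is whether replacing a methoxy group on the shared core with hydroxyl would do so.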